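Cytotoxicity notes on three measured analogues and a fourth

The source may hold more compounds than are shown below. What is called first, only, known or untested is meant among the compounds shown, and "the series" means these compounds.

Compound 1, `CCOC(=O)c1c(-c2cccc(OCC)c2)[nH]c2cc(OC)ccc2c1=O`, in an ADME assay on Raji cells (Homo sapiens) for cytotoxicity, read by luminescence, with a stated time of 72 h (on this read-out lower numbers stand for an effect already at smaller amounts and higher numbers for an effect only at larger amounts of compound), reaches only the limit > 21500 nM.
Compound 2, `CCCCOc1cccc(-c2[nH]c3cc(OC)ccc3c(=O)c2C(=O)OCC)c1`, in this assay reaches only the limit > 21500 nM.
Compound 3, `CCOC(=O)c1c(-c2cccc([N+](=O)[O-])c2)[nH]c2cc(OC)ccc2c1=O`, in this assay reaches only the limit > 21500 nM.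

For the measured compounds named here, every number so far is a limit, not a value: all three compounds stand at the limit of > 21500 nM in this assay, at which 3 of the 3 values shown sit. Compound 2 therefore has no placing among the others beyond that limit. The steps a step that the two limits leave unreadable from compound 1 to compound 2, a step that the two limits leave unreadable from compound 1 to compound 3 and a step that the two limits leave unreadable from compound 2 to compound 3 are all hidden by the limits and carry no readable size.

Compound 4, `CCOC(=O)c1c(-c2cccc(O)c2)[nH]c2cc(OC)ccc2c1=O`, differs from compound 2 by hydrogen in place of butyl on an oxygen on an aromatic ring; the same difference, cut one bond further out, reads butoxy to hydroxy. Going by the values given here, no measured step covers this change directly. Among the compounds with values here, the only related step, from compound 1 to compound 2, is a step that the two limits leave unreadable from compound 1 to compound 2, which is unreadable, and the two nitro steps are unreadable as well. Nothing among the three measurements shows any change in this assay that rises above the scatter, so no step beyond the scatter is expected here either.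

For compound 4 the expected step is a step that the limit leaves unreadable from compound 2 to compound 4, most likely ending at the same limit. Compound 4 is therefore estimated at 30000 nM, within 15000 nM to 100000 nM.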

Compound 4, half-maximal effective concentration: > 21500 nM
Compound 4: no number, only a limit; the forecaster's own chance of this, stated with the estimate: 80%; the middle value is on the limit's open side.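

No new step can be read: in this assay compound 4 reaches only a limit, > 21500 nM, so its steps from compound 1, compound 2 and compound 3 remain unreadable, with the whole series resting on one limit: the limit of > 21500 nM in this assay, at which 4 of the 4 values shown sit.

The compounds shown leave open whether exchanging hydroxy, ethoxy, butoxy or nitro changes the effect in this assay at all.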